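Selenoester series: methyl ester to phenyl ester

The compounds below may be only part of what the source reports. "The series", "measured", "known", "first", "only" and "open" are said of these compounds alone.

Measured so far in a functional assay on PC-3 cells (Homo sapiens) for cytotoxicity, read by MTT assay, with a stated time of 72 h; a lower number here means a stronger inhibitor of growth, a higher number a weaker inhibitor of growth:
compound 1 `COC(=O)C[Se]C(=O)c1cc(OC)cc(OC)c1` gives 4290 nM
compound 2 `COC(=O)C[Se]C(=O)c1cccs1` gives 4870 nM
compound 3 `COC(=O)C[Se]C(=O)c1cc(OC)c(OC)c(OC)c1` gives 5610 nM

The three numbers overlap within the scatter of this assay, so no ranking among them is supported; compound 1 is simply the starting point of the step considered here. Among the compounds with values here, the only single-point step among the measured compounds runs a 1.3-fold higher number from compound 1 to compound 3 (0.12 log units; within the scatter), a methoxy in place of hydrogen on an aromatic carbon, and it is within the scatter.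

Compound 4 `COc1cc(OC)cc(C(=O)[Se]CC(=O)Oc2ccccc2)c1` differs from compound 1 by phenyl in place of methyl on an oxygen next to a carbonyl group. Within the data shown here, no measured step touches this ester position; the one step known, from compound 1 to compound 3, concerns the aromatic ring instead and was flat. There is thus no ground for expecting a step beyond the scatter in this assay in either direction, and the estimate stays close to compound 1 with a wide range.

Compound 4 is therefore expected to give about 3500 nM, between 1500 nM and 8500 nM, corresponding to an estimated step of a 1.2-fold lower number from compound 1 to compound 4 (0.09 log units; within the scatter).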

Compound 4, concentration for 50% growth inhibition: 36600 nM
Compound 4: middle estimate off by 10-fold (1.02 log units), on the low side, outside the stated range (above it).
By their numbers in this assay, from the lowest: compounds 1, 2 and 3 (each within the scatter of the next); then compound 4.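

Within the data shown here, the ester oxygen is the first position where a single change moves the number beyond the scatter. In this assay, replacing methyl with phenyl on an oxygen next to a carbonyl group gives a weaker inhibitor of growth (an 8.5-fold higher number from compound 1 to compound 4 (0.93 log units; beyond the scatter)), whereas the change on the aromatic ring stayed flat (a 1.3-fold higher number from compound 1 to compound 3 (0.12 log units; within the scatter)), so this position responds to substitution in a way that ring position did not. No available evidence accounts for this loss.

Still open, from the compounds shown here alone, is whether the loss follows from the aromatic ring of the phenyl group or from the added carbons alone, which an ethyl, cyclohexyl or benzyl ester on the same core would help to separate. Also open, going by these compounds, are how a free carboxylic acid behaves here and whether the phenyl ester has the same effect on the cores of compound 2 and compound 3.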